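A few compounds are considered here, and "the series" means these few. Any claim that something is new, unique, unknown or untested is made for them only; others in the source may bear on it.

Of the compounds shown here, three have so far been tested in a functional assay on MCF7 cells (Homo sapiens) for inhibition, read by MTT assay, with a stated time of 72 h; on this read-out higher numbers stand for weaker inhibition and lower numbers for stronger inhibition. Compound 1 `O=C(Nc1ccc(Oc2ccnc3[nH]ccc23)cc1)c1cn(-c2ccc(Cl)cc2)c2ccccc2c1=O` gives 1590 nM in this assay. Within the data shown here, compound 2 `O=C(Nc1ccc(Oc2ccnc3[nH]ccc23)cc1)c1cn(-c2ccc(Br)cc2)c2ccccc2c1=O` differs from it only by bromo in place of chloro on an aromatic carbon, and in this assay compound 2 gives 610 nM, so that the single swap brought a 2.6-fold lower number from compound 1 to compound 2 (0.42 log units; beyond the scatter). Compound 3 `Cn1ccc2c(Oc3ccc(NC(=O)c4cn(-c5ccc(Cl)cc5)c5ccccc5c4=O)cc3F)ccnc21` is built on a different core; how the two cores differ is not broken down here. In this assay compound 3 gives 2120 nM, a value within the scatter of compound 1 but beyond the scatter of compound 2.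

Compound 4 `Cn1ccc2c(Oc3ccc(NC(=O)c4cn(-c5ccc(Br)cc5)c5ccccc5c4=O)cc3F)ccnc21` has not yet been measured. It stands to compound 3 exactly as compound 2 stands to compound 1: bromo in place of chloro on an aromatic carbon. Among the measured compounds shown here, since the swap sits in the same kind of place in both pairs, the step seen once is the only guide available. For the measured compounds named here, a step of roughly the same size is expected here, a 2.5-fold lower number from compound 3 to compound 4 (0.40 log units; beyond the scatter), because a 2.6-fold lower number from compound 1 to compound 2 (0.42 log units; beyond the scatter) is the sole measured example of this swap and rests on a single pair. The estimate for compound 4 in this assay is therefore 850 nM, with a plausible range from 400 nM to 1900 nM.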

Compound 4, half-maximal inhibitory concentration: 1830 nM
For compound 4 the middle estimate is 2.2-fold (0.33 log units) below the measured one; the measured number falls inside the stated range.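

On the core of compound 3, putting 4-bromophenyl in place of 4-chlorophenyl brings a 1.2-fold lower number from compound 3 to compound 4 (0.06 log units; within the scatter) in this assay, so on this core the swap has no effect that can be told apart from ordinary repeat variation. One step lies beyond the scatter and the other within it, yet the two do not truly disagree when set side by side: the same change on two cores in this assay, a 2.6-fold lower number (0.42 log units; beyond the scatter) from compound 1 to compound 2 and a 1.2-fold lower number (0.06 log units; within the scatter) from compound 3 to compound 4, 2.3-fold (0.35 log units) apart, within the scatter of two such steps. This shows that the swap can be carried to the second core with no clear sign of a different outcome, but two pairs cannot show that the step has one fixed size on both cores, nor can they rule out a real difference between the cores.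

The compounds shown leave open what other groups in the place of the halogen, such as iodo, an amine or a carboxylic acid, would do on either core. They also leave open whether the bromo swap would behave in the same way on a third core.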